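The compounds below may be only part of what the source reports. "The series", "measured", "known", "first", "only" and "open" are said of these compounds alone.

Of the compounds shown here, two have so far been measured in an assay on HEK293 cells for displacement of a labelled ligand from Melanocortin receptor 4 (Homo sapiens); a higher number here means a weaker inhibitor, a lower number a stronger inhibitor. Compound 1 `CCC(C)[C@H](N)c1cc(C(F)(F)F)ccc1N1CCN(C(=O)CCc2ccc(Cl)cc2)CC1` gives 86 nM in this assay. Compound 2 `CC(C)C[C@H](N)c1cc(C(F)(F)F)ccc1N1CCN(C(=O)CCc2ccccc2Cl)CC1` gives 1700 nM in this assay, the higher of the two numbers, and its value lies well apart from that of compound 1. Because the two compounds differ in more than one place, the pair of values alone does not show which part of the difference carries the gap.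

Compound 3 `CC(C)C[C@H](N)c1cc(C(F)(F)F)ccc1N1CCN(C(=O)CCc2ccc(O)cc2)CC1` has not yet been measured. It differs from compound 2 by 4-hydroxyphenyl in place of 2-chlorophenyl on a saturated chain carbon, two bonds along the chain from a carbonyl carbon. Going by the values given here, no measured pair shows this change directly, so the expectation rests only on the two values known. The step is expected to be a 5.7-fold lower number from compound 2 to compound 3 (0.75 log units; beyond the scatter), a lowering of the number beyond the scatter, though with wide uncertainty. Compound 3 is expected to give 300 nM in this assay, with a range from 70 nM to 1500 nM.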

Compound 3, inhibition constant: > 10000 nM
Compound 3: a limit, no number; the forecaster's own chance of this, stated with the estimate: 5%; middle value at least 33-fold (1.52 log units) away from the limit.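

The value of compound 3 is a limit of the assay and not a number: the limit of > 10000 nM in this assay, at which 1 of the 3 values shown sits. Going by these compounds alone, replacing 2-chlorophenyl with 4-hydroxyphenyl on a saturated chain carbon, two bonds along the chain from a carbonyl carbon, gives an at least 5.8-fold higher number from compound 2 to compound 3 (0.76 log units; beyond the scatter), the first step that can be read at a single place. This position is therefore not indifferent to the group it carries, and the change moves the number upward, with only a lower bound on the size of the step.

The change swaps the substituent and its place on the ring at once, so the compounds shown do not separate the two. They also leave open how 4-methoxyphenyl, 2-hydroxyphenyl or an unsubstituted phenyl would behave at this position.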